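This account rests on a few compounds, and the source may have more. Where it says the series, first, only, none or still open, it means among the compounds named here.

Measured so far:
compound 1, `O=C(NCCOCc1ccccc1)n1c(=O)oc2ccccc21`: 649 nM
compound 2, `O=C(c1ccc(Cl)cc1)c1ccc2c(c1)oc(=O)n2C(=O)NCCCCc1ccccc1`: 14 nM

In an assay on HEK293 cells for inhibition of acid ceramidase (Homo sapiens), with a stated time of 10 min (on this read-out higher numbers stand for weaker inhibition and lower numbers for stronger inhibition), compound 1 gives 649 nM, while compound 2 gives 14 nM. Of the two numbers, compound 2 holds the lower one, and the gap to compound 1 lies beyond the usual scatter, so compound 2 stands as the stronger inhibitor of this pair.

Compound 3, `Cc1ccc2c(c1)oc(=O)n2C(=O)NCCCCc1ccccc1`, has not yet been measured in this assay. It differs from compound 2 at one spot: methyl in place of (4-chlorophenyl)carbonyl on an aromatic carbon. The change sits on an aromatic carbon of the fused ring system, meta to a fused ring and para to a fused ring.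

Among the compounds with values here, no step between measured compounds matches this exchange, so the expectation rests on the two numbers alone. Because compound 2 gives 14 nM with the larger group present, compound 3 is expected to move toward a higher number, by an 11-fold higher number from compound 2 to compound 3 (1.03 log units; beyond the scatter). The estimated value for compound 3 in this assay is 150 nM, within a range from 30 nM to 700 nM.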

Compound 3, half-maximal inhibitory concentration: 66 nM
Compound 3: the middle estimate sits 2.3-fold (0.36 log units) above what was measured, and the stated range covers the measured number.
By their numbers in this assay, from the lowest: compound 2; then compound 3; then compound 1.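

Within the data shown here, exchanging (4-chlorophenyl)carbonyl for methyl on this aromatic carbon gives a 4.7-fold higher number from compound 2 to compound 3 (0.67 log units; beyond the scatter) in this assay, the first evidence that the group at this position affects inhibition. The step also shows that inhibition does not depend on the whole (4-chlorophenyl)carbonyl group: with only methyl at this carbon, compound 3 still gives 66 nM, although the larger group gives the lower number. No measurement at hand bears on the cause of this step.

The compounds shown leave open which part of the larger group carries the difference, since a benzoyl group without chlorine or a plain phenyl on this carbon would separate the chlorine, the carbonyl and the ring. On these data alone, how an amine or a carboxylic acid would read at this carbon also remains open.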